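This account rests on a few compounds, and the source may have more. Where it says the series, first, only, none or still open, it means among the compounds named here.

In a functional assay on HepG2 cells (Homo sapiens) for antiproliferative activity, read by MTT assay, with a stated time of 48 h (a higher number here means a weaker inhibitor, a lower number a stronger inhibitor), compound 1 (`COc1ccc(/C=C/c2cc(OC)cc(OC)c2/C=C/C(=O)c2ccc(C)cc2)cc1`) gives 4.8 ug/mL while compound 2 (`COc1ccc(/C=C/c2cc(OC)cc(OC)c2/C=C/C(=O)c2ccc(C(F)(F)F)cc2)cc1`) gives 18.7 ug/mL and compound 3 (`COc1ccc(/C=C/c2cc(OC)cc(OC)c2/C=C/C(=O)c2ccc(N)cc2)cc1`) gives 7.5 ug/mL on the same core. Compound 3 thus stands within the scatter of one neighbour (a 1.6-fold higher number from compound 1 to compound 3 (0.19 log units; within the scatter)) and beyond the scatter of the other (a 2.5-fold lower number from compound 2 to compound 3 (0.40 log units; beyond the scatter)). Compound 4 (`COc1ccc(/C=C/c2cc(OC)cc(OC)c2/C=C/C(=O)c2ccccc2C)cc1`) departs from compound 3 by one exchange (2-methylphenyl in place of 4-aminophenyl on a carbonyl carbon), 2-methylphenyl in place of 4-aminophenyl on a carbonyl carbon. The measured exchange of methyl for amino stayed within the scatter, and the modest step came with trifluoromethyl (a 3.9-fold higher number from compound 1 to compound 2 (0.59 log units; beyond the scatter)), which is absent here. Among the compounds with values here, no measured compound carries 2-methylphenyl, so that group is untested. Nothing beyond the scatter is therefore expected in this assay for this change. The expected step is small (a 1.3-fold lower number from compound 3 to compound 4 (0.10 log units; within the scatter)). Compound 4 is estimated at 6 ug/mL within an expected range (2.5 ug/mL to 14 ug/mL).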

Compound 4, half-maximal inhibitory concentration: 5.3 ug/mL
Compound 4: middle estimate off by 1.1-fold (0.05 log units), on the high side; measured number inside the range.
By their numbers in this assay, from the lowest: compounds 1, 4 and 3 (each within the scatter of the next); then compound 2.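

In this assay, 2-methylphenyl on the carbonyl carbon reads the same within the scatter as 4-methylphenyl (a 1.1-fold higher number from compound 1 to compound 4 (0.04 log units; within the scatter)) and as 4-aminophenyl (a 1.4-fold lower number from compound 3 to compound 4 (0.15 log units; within the scatter)), so the methyl group's place on the ring makes no measurable difference here. Against 4-(trifluoromethyl)phenyl the new group shows a clear gap (a 3.5-fold lower number from compound 2 to compound 4 (0.55 log units; beyond the scatter)), leaving that group as the only one apart from the others. No evidence is available to explain these results. As far as these compounds go, it remains open how a carboxylic acid, a hydroxyl or a longer chain would read at this carbonyl-bound ring in this assay.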